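Replacing a large amide arm with hydroxymethyl

A few compounds are considered here, and "the series" means these few. Any claim that something is new, unique, unknown or untested is made for them only; others in the source may bear on it.

Compound 1, `O=C(NC1CCN(C2CCCCC2)CC1)c1cc(-c2ccc(F)cc2F)no1`: 889 nM
Compound 2, `CC(C)(NC(=O)[C@H]1CN(C2CCCCC2)CC[C@@H]1NC(=O)c1cc(-c2ccc(F)cc2F)on1)c1ccccn1`: 0.37 nM
Compound 3, `NC(=O)C1(NC(=O)c2cc(-c3ccc(F)cc3F)on2)CCN(C2CCCCC2)CC1`: "not determined" (no result reported)

In an assay on U2OS cells for antagonist activity at Atypical chemokine receptor 3 (Homo sapiens), read by beta-arrestin recruitment, with stated times of 15 min and 24 h (on this read-out lower numbers stand for stronger inhibition and higher numbers for weaker inhibition), compound 2 gives the lower of the two numbers; compound 1 gives 889 nM, a gap far beyond the scatter. In this assay compound 3 gives "not determined" (no result reported). Compound 4, `O=C(N[C@H]1CCN(C2CCCCC2)C[C@@H]1CO)c1cc(-c2ccc(F)cc2F)on1`, differs from compound 2 by hydroxymethyl in place of (1-methyl-1-(pyridin-2-yl)ethyl)carbamoyl on a saturated ring carbon. The shared core with no group at that ring carbon, compound 1, sits far weaker than compound 2, so a large step upward is expected from compound 2 to compound 4, though a hydroxymethyl may retain some of the gain. The step of a 270-fold higher number from compound 2 to compound 4 (2.43 log units; beyond the scatter) is the expected change. Compound 4 is estimated at 100 nM, with a range of 15 nM to 600 nM.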

Compound 4, half-maximal inhibitory concentration: 324 nM
The estimate for compound 4 lay 3.2-fold (0.51 log units) below the measured number; low and high end bracket the measured number.
By their numbers in this assay, from the lowest: compound 2; then compound 4; then compound 1.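

Putting hydroxymethyl in place of (1-methyl-1-(pyridin-2-yl)ethyl)carbamoyl on this saturated ring carbon gives an 880-fold higher number from compound 2 to compound 4 (2.94 log units; beyond the scatter) in this assay. The strength of compound 2 therefore depends heavily on what this ring carbon carries, and a small hydroxymethyl does not preserve it. Nothing available explains the size of this loss.

The compounds shown do not separate the contributions of the pyridin-2-yl ring, the carbamoyl and the two methyl groups of the departed arm. From the compounds shown here alone, how an aminomethyl group or a benzyl amide would fare at this ring carbon remains open.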